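The compounds below may be only part of what the source reports. "The series", "measured", "known", "first", "only" and "open" are said of these compounds alone.

The measured compounds:

Compound 1 `CN(C)C(=O)C[C@H](CSc1ccccc1)Nc1c(C(=O)N/N=C/c2ccc(F)cc2)cnc2c(C(F)(F)F)cccc12`. In an ADME assay on Vero cells (Chlorocebus sabaeus) for cytotoxicity, read by MTT assay, with a stated time of 72 h (on this read-out lower numbers stand for stronger inhibition and higher numbers for weaker inhibition), compound 1 gives > 62.5 ug/mL, which is a limit of the assay and not a number.
Compound 2 `CN(C)C(=O)C[C@H](CSc1ccccc1)Nc1c(C(=O)N/N=C/c2ccc(OC(F)(F)F)cc2)cnc2c(C(F)(F)F)cccc12`. In this assay compound 2 gives > 62.5 ug/mL, again a limit rather than a number.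
Compound 3 `CN(C)C(=O)C[C@H](CSc1ccccc1)Nc1c(C(=O)N/N=C/c2ccc(F)cc2)cnc2ccc(F)cc12`. In this assay compound 3 gives > 62.5 ug/mL, also a limit.

Compound 1 and compound 2 differ in one place: trifluoromethoxy in place of fluoro on an aromatic carbon. The step that the two limits leave unreadable from compound 1 to compound 2 cannot be sized, since both values sit at the limit of > 62.5 ug/mL in this assay, at which 3 of the 3 values shown sit. Compound 3 carries a different core; the difference between the core of compound 1 and the core of compound 3 is not broken down here.

Compound 4 `CN(C)C(=O)C[C@H](CSc1ccccc1)Nc1c(C(=O)N/N=C/c2ccc(OC(F)(F)F)cc2)cnc2ccc(F)cc12` has not yet been measured in this assay. It differs from compound 3 by trifluoromethoxy in place of fluoro on an aromatic carbon, and the surroundings of the place are described in the same words for both pairs, so this is the same change already seen from compound 1 to compound 2.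

The expectation for compound 4 rests on compound 3 sitting at the limit of > 62.5 ug/mL in this assay, at which 3 of the 3 values shown sit, and on the measured pair showing no readable movement away from that limit. The step that the limit leaves unreadable from compound 3 to compound 4 is therefore expected to be small. Compound 4 is estimated to give 100 ug/mL in this assay, with a range from 40 ug/mL to 300 ug/mL, most likely reported once more only as a limit.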

Compound 4, half-maximal inhibitory concentration: > 62.5 ug/mL
Compound 4: only a limit was reported; the forecaster's own chance of this, stated with the estimate: 85%; the middle value does not contradict the limit.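

In this assay compound 4 gives > 62.5 ug/mL, which is a limit of the assay and not a number. Within the data shown here, the step from compound 3 to compound 4 therefore cannot be read, any more than the one from compound 1 to compound 2: the limit of > 62.5 ug/mL in this assay, at which 4 of the 4 values shown sit. The compounds shown leave open whether trifluoromethoxy in place of fluoro changes the value at all, and where the true value of each of the four compounds lies.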